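Nitro on the phenyl of compound 2

This account rests on a few compounds, and the source may have more. Where it says the series, first, only, none or still open, it means among the compounds named here.

Measured in a functional assay on SF-268 cells (Homo sapiens) for antiproliferative activity, read by MTT assay, with a stated time of 96 h; on this read-out lower numbers stand for stronger inhibition and higher numbers for weaker inhibition:
- compound 1 `O=C1NNC(=O)C2(CSC3=C2C(=O)c2ncccc2C3=O)N1`: 4820 nM
- compound 2 `O=C1C2=C(C(=O)c3ncccc31)C1(CS2)NC(=O)N(c2ccccc2)C1=O`: 1700 nM
- compound 3 `O=C1NN(c2ccccc2)C(=O)C2(CSC3=C2C(=O)c2ncccc2C3=O)N1`: 2200 nM

Compound 2 at 1700 nM and compound 3 at 2200 nM lie within the scatter of each other. Compound 1 carries the higher number, and its gap to compound 2 is beyond the scatter.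

Next in the series is compound 4 `O=C1C2=C(C(=O)c3ncccc31)C1(CS2)NC(=O)N(c2ccc([N+](=O)[O-])cc2)C1=O`, which departs from compound 2 by nitro in place of hydrogen on an aromatic carbon. This is nitro in place of hydrogen on an aromatic carbon, para to a large group, so phenyl becomes 4-nitrophenyl.

Among the measured compounds shown here, only one measured step is available, a 2.2-fold lower number from compound 1 to compound 3 (0.34 log units; beyond the scatter), with phenyl in place of hydrogen on an amide-type nitrogen in a ring. That step is modest and bears only indirectly, since it introduces the phenyl and does not alter a group on it. For the measured compounds named here, no measured compound carries a substituent on the phenyl, so the direction of the new step is open. In this assay, no change beyond the scatter is therefore expected, though a modest move either way remains possible.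

The expected step is a 1.1-fold lower number from compound 2 to compound 4 (0.03 log units; within the scatter).

For compound 4 the estimated value is 1600 nM, with an expected range of 600 nM to 4200 nM.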

Compound 4, half-maximal inhibitory concentration: 1520 nM
Beside the measured number, compound 4's estimate is 1.1-fold (0.02 log units) above it; low and high end bracket the measured number.
By their numbers in this assay, from the lowest: compounds 4, 2 and 3 (each within the scatter of the next); then compound 1.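

In this assay, among the compounds shown here, the nitro group gives the first reading of a substituent on the phenyl: a 1.1-fold lower number from compound 2 to compound 4 (0.05 log units; within the scatter). The earlier step, a 2.2-fold lower number from compound 1 to compound 3 (0.34 log units; beyond the scatter), showed only what bringing in a phenyl does on a closely related core, whereas this one shows that the phenyl of compound 2 can carry nitro on an aromatic carbon, para to a large group, with the number staying within the scatter. So phenyl to 4-nitrophenyl adds three heavy atoms at this place without a measurable shift in this assay, though no measurement on hand accounts for that outcome.

A single substituent at a single place cannot show whether this carbon accepts other groups equally, so an amine, a carboxylic acid, a methoxy group or a longer chain there could still move the number beyond the scatter in either direction. On these data alone, it also remains open whether nitro at the same place on the phenyl of compound 3 would give a similarly small step, or whether the result holds only for the core of compound 2.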